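This account rests on a few compounds, and the source may have more. Where it says the series, first, only, none or still open, it means among the compounds named here.

Compounds measured in a functional assay on isolated protein for inhibition of Glucose-dependent insulinotropic receptor (Rattus norvegicus), read by HTRF and cAMP accumulation; on this read-out higher numbers stand for an effect only at larger amounts of compound and lower numbers for an effect already at smaller amounts: compound 1 `Cc1nc(S(C)(=O)=O)ccc1Oc1ncnc(OC2CCN(C(=O)OC3CCC3)CC2)c1F` gives 167 nM; compound 2 `Cc1nc(S(C)(=O)=O)ccc1Oc1ncnc(OC2CCN(C(=O)OC3(C(F)(F)F)CCC3)CC2)c1F` gives 63.3 nM; compound 3 `Cc1nc(S(C)(=O)=O)ccc1Oc1ncnc(OC2CCN(C(=O)OC3(C(F)(F)F)COC3)CC2)c1F` gives 342 nM.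

Compound 1 stands second highest of the three numbers. Compound 3 is nearest, a 2.0-fold higher number from compound 1 to compound 3 (0.31 log units; beyond the scatter); compound 2 is furthest, a 2.6-fold lower number from compound 1 to compound 2 (0.42 log units; beyond the scatter).

Compound 4 `Cc1nc(S(C)(=O)=O)ccc1Oc1ncnc(OC2CCN(C(=O)C(F)(F)F)CC2)c1F` is not yet measured. It differs from compound 1 by trifluoromethyl in place of cyclobutyloxy on a carbonyl carbon, a change that, cut one bond further out, reads cyclobutyloxycarbonyl to (trifluoromethyl)carbonyl. Within the data shown here, no measured step removes the ring altogether. The two steps from compound 1 both touched that ring and both were modest: exchanging it raised the number, adding trifluoromethyl lowered it. Removing the ring is a larger change, and a modest rise in this assay is expected. Compound 4 is estimated at 400 nM, between 120 nM and 1500 nM. For compound 4 that means an expected 2.4-fold higher number from compound 1 to compound 4 (0.38 log units; beyond the scatter).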

Compound 4, half-maximal effective concentration: 880 nM
Compound 4: middle estimate off by 2.2-fold (0.34 log units), on the low side, within the range that was stated.
By their numbers in this assay, from the lowest: compound 2; then compound 1; then compound 3; then compound 4.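

In this assay, trifluoromethyl in place of cyclobutyloxy on the carbonyl carbon gives a 5.3-fold higher number from compound 1 to compound 4 (0.72 log units; beyond the scatter) and so costs more than either ring exchange did, showing that this position does not tolerate losing the whole group. Even against the oxetane-bearing compound there is a 2.6-fold higher number from compound 3 to compound 4 (0.41 log units; beyond the scatter) and, against the best compound, a 14-fold higher number from compound 2 to compound 4 (1.14 log units; beyond the scatter) as the only large step in the series. No measurement shown gives a reason for these steps.

Going by these compounds, whether the oxygen or the ring matters more stays open. A methoxy group or a cyclobutyl group set directly on the carbonyl carbon would separate the two.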